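Small Alkyl Ester Expected to Lift Cytotoxicity Off the Limit

The source may hold more compounds than are shown below. What is called first, only, known or untested is meant among the compounds shown, and "the series" means these compounds.

Compound 1 `C=C1C(=O)O[C@H]2CC3=C[C@H](C/C(C)=C/[C@@H](OC(=O)/C=C/c4ccc(N(C)C)cc4)[C@H]12)OC3=O` is the starting point. In a functional assay on A549 cells (Homo sapiens) for cytotoxicity, read by MTT assay, with a stated time of 48 h (on this read-out higher numbers stand for weaker inhibition and lower numbers for stronger inhibition), compound 1 gives only a limit, > 10000 nM. Compound 2 `C=C1C(=O)O[C@H]2CC3=C[C@H](C/C(C)=C/[C@@H](OC(=O)CCCCBr)[C@H]12)OC3=O` carries a 4-bromobutyl group on the carbonyl carbon instead. In this assay compound 2 also gives only a limit, > 10000 nM. Compound 3 `C=C1C(=O)O[C@H]2CC3=C[C@H](C/C(C)=C/[C@@H](OC(=O)C4CC4)[C@H]12)OC3=O` carries a cyclopropyl group there, and in this assay compound 3 gives 3200 nM. Compound 1 thus sits at the limit of the assay, where most of the measured values lie (the limit of > 10000 nM in this assay, at which 2 of the 3 values shown sit). The step that the two limits leave unreadable from compound 1 to compound 2, whereas the step of an at least 3.1-fold lower number from compound 1 to compound 3 (0.49 log units; beyond the scatter) and the step of an at least 3.1-fold lower number from compound 2 to compound 3 (0.49 log units; beyond the scatter).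

Compound 4 `C=C1C(=O)O[C@H]2CC3=C[C@H](C/C(C)=C/[C@@H](OC(=O)C(C)(C)CC)[C@H]12)OC3=O` has not been measured. It differs from compound 1 in one place: 1,1-dimethylpropyl in place of 2-(4-(dimethylamino)phenyl)ethenyl on a carbonyl carbon. The steps of an at least 3.1-fold lower number from compound 1 to compound 3 (0.49 log units; beyond the scatter) and an at least 3.1-fold lower number from compound 2 to compound 3 (0.49 log units; beyond the scatter) bear most closely on this change, each exchanging a larger ester group for a small one on the carbonyl carbon and each lowering the number at least modestly. A comparable lowering is expected in this assay for compound 4, although a 1,1-dimethylpropyl group need not match the cyclopropyl outcome exactly, so some chance remains that only a limit is reported. The estimate for compound 4 is therefore 5000 nM, between 2000 nM and 15000 nM, which means an expected step of an at least 2.0-fold lower number from compound 1 to compound 4 (0.30 log units; that floor lies within the scatter).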

Compound 4, half-maximal inhibitory concentration: 2200 nM
Beside the measured number, compound 4's estimate is 2.3-fold (0.36 log units) above it, within the range that was stated.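

With 1,1-dimethylpropyl on the carbonyl carbon, this assay shows a second clear lowering, so the gain is no longer tied to the cyclopropyl group alone: the record gives an at least 4.5-fold lower number from compound 1 to compound 4 (0.65 log units; beyond the scatter) and an at least 4.5-fold lower number from compound 2 to compound 4 (0.65 log units; beyond the scatter). Compound 3 and compound 4 cannot be told apart, with a 1.5-fold lower number from compound 3 to compound 4 (0.16 log units; within the scatter), so at this position a group with no ring serves as well as the cyclopropyl ring in this assay. The two steps from the larger ester groups are floors only, and their true size stays unknown: the limit of > 10000 nM in this assay, at which 2 of the 4 values shown sit.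

Among these four compounds, the ester groups of compound 1 and compound 2 go against any reading that all ester groups on the shared core give a measurable number, yet these two groups differ too much to show which feature separates them from the other two. From the compounds shown here alone, whether an unbranched pentyl chain would behave like 1,1-dimethylpropyl or like 4-bromobutyl stays open, as does the outcome for a chain ending in an amine or a carboxylic acid.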